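This account rests on a few compounds, and the source may have more. Where it says the series, first, only, none or still open, it means among the compounds named here.

Measured compounds:
- compound 1, `CCCC(=O)OCSc1ccccc1C(=O)NCCC(N)=O`, > 100 uM
- compound 2, `CCCC(=O)OCSc1ccccc1C(=O)NCCCNC(C)=O`, 21.1 uM
- compound 3, `CCCC(=O)OCSc1ccccc1C(=O)NCCCCCNC(C)=O`, 9.2 uM

Compound 1 stands at the top of the numbers shown. In an ADME assay on CEM-SS cells (Homo sapiens) for cytotoxicity, read by XTT assay, with a stated time of 6 days (a higher number here means that more compound is tolerated, a lower number that less compound is tolerated), compound 1 gives > 100 uM, and this value is a limit of the assay rather than a number (the limit of > 100 uM in this assay, at which 1 of the 3 values shown sits). Compound 2 gives 21.1 uM and compound 3 gives 9.2 uM in this assay.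

The unmeasured compound 4, `CCCC(=O)OCSc1ccccc1C(=O)NCC(=O)OC`, differs from compound 1 in one place: methoxycarbonyl in place of carbamoylmethyl on a saturated chain carbon bound to an amide-type nitrogen.

The measured steps all run from compound 1 toward longer chains ending in an acetamido group: an at least 4.7-fold lower number from compound 1 to compound 2 (0.67 log units; beyond the scatter) and an at least 10-fold lower number from compound 1 to compound 3 (1.03 log units; beyond the scatter), with a 2.3-fold lower number from compound 2 to compound 3 (0.36 log units; beyond the scatter) between them. Each lowers the tolerated concentration. None of them exchanges a carbamoyl for an ester, so they bear on compound 4 only in showing that any change at this chain has moved the number downward from the limit where compound 1 sits. Because compound 1 shows only a limit (the limit of > 100 uM in this assay, at which 1 of the 3 values shown sits), the size of the step to compound 4 is uncertain; a modest decrease, or none beyond the scatter, is expected, as an at least 1.6-fold lower number from compound 1 to compound 4 (0.22 log units; that floor lies within the scatter). Compound 4 is therefore estimated at 60 uM, in the range 20 uM to 150 uM.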

Compound 4, half-maximal toxic concentration: 27.3 uM
Estimate against measurement, compound 4: 2.2-fold (0.34 log units) above; measured number inside the range.
By their numbers in this assay, from the lowest: compound 3; then compounds 2 and 4 (each within the scatter of the next). At a limit, above all of these: compound 1.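

In this assay, putting methoxycarbonyl in place of carbamoylmethyl on a saturated chain carbon bound to an amide-type nitrogen gives an at least 3.6-fold lower number from compound 1 to compound 4 (0.56 log units; beyond the scatter), so the fall from the top of the series is not confined to chains ending in an acetamido group. For compound 1, > 100 uM is a limit of the assay and not a number: the limit of > 100 uM in this assay, at which 1 of the 4 values shown sits. Against the acetamido-ended chains, the change gives a 3.0-fold higher number from compound 3 to compound 4 (0.47 log units; beyond the scatter) and a 1.3-fold higher number from compound 2 to compound 4 (0.11 log units; within the scatter), so methoxycarbonyl and 2-acetamidoethyl cannot be told apart at this place, while 4-acetamidobutyl stays clearly separate from methoxycarbonyl.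

The compounds shown do not separate the ester from the chain that carries it, since the step from 2-carbamoylethyl to (methoxycarbonyl)methyl changes the end group and the chain together. They also leave open how a carboxylic acid or an amine at the chain end, or a methyl ester on a longer chain, would stand in this assay.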